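The source may hold more compounds than are shown below. What is called first, only, known or untested is meant among the compounds shown, and "the series" means these compounds.

Series notes, cytotoxicity. The set holds two cores. Compound 1 `COc1ccccc1S(=O)(=O)/C=C/c1ccccn1` and compound 2 `COc1ccccc1S(=O)(=O)/C=C/c1cccc(Cl)n1` share one core; compound 3 `COc1ccc(S(=O)(=O)/C=C/c2cccnc2)cc1` and the not yet measured compound 4 `COc1ccc(S(=O)(=O)/C=C/c2cccnc2Cl)cc1` share the other. How the core of compound 3 differs from that of compound 1 is not broken down here; the two have the same atoms, joined differently.

In an ADME assay on BV-2 cells (Mus musculus) for cytotoxicity, with a stated time of 24 h, tested at 10 uM (a lower number here means a stronger effect, a higher number a weaker effect of the compound at the concentration tested), compound 1 gives 100%. Compound 2 gives 100% in this assay, so that the step of no change at the digits printed from compound 1 to compound 2 (within the scatter) comes with chloro in place of hydrogen on an aromatic carbon. In this assay compound 3 gives 99.5%, within the scatter of compound 1 and of compound 2.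

Compound 4 differs from compound 3 by chloro in place of hydrogen on an aromatic carbon. This is the same kind of change as from compound 1 to compound 2, not the same: there the chloro sits meta to a large group, here ortho to a large group. Since the earlier step left the read-out unchanged, a step of a number 0.5 percentage points lower from compound 3 to compound 4 (within the scatter) is expected, within the scatter. For compound 4 the estimate in this assay is 99%, between 87% and 105%.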

Compound 4, a percentage reported as activity, at one concentration (the size of the read-out at that concentration, not a potency): 100%
Compound 4: the middle estimate sits 1 percentage points below what was measured; the measured number falls inside the stated range.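

In this assay, chloro in place of hydrogen on an aromatic carbon gives a number 0.5 percentage points higher from compound 3 to compound 4 (within the scatter), and the two steps agree when set side by side: the same change on two cores in this assay, no change at the digits printed (within the scatter) from compound 1 to compound 2 and a number 0.5 percentage points higher (within the scatter) from compound 3 to compound 4, 0.5 percentage points apart, within the scatter of two such steps On these two cores, then, the change carries over with the read-out staying within the scatter, even though the chloro sits at a different place on each core. This does not show that the change is neutral in general: it rests on two pairs, one read-out and one tested concentration, with all four compounds close together, so it says nothing about a core that gives a clearly lower number.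

The compounds shown hold only hydrogen or chloro at the changed place, so the outcome with an amine, a carboxylic acid or a longer chain there stays open. Also open, as far as these compounds go, is whether any change to the methoxy group or the sulfonyl group would move the number in this assay beyond the scatter.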